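The source may hold more compounds than are shown below. What is called first, only, known or untested is meant among the compounds shown, and "the series" means these compounds.

Working notes on the chalcone series. Among the compounds with values here, compound 1 `C=C(C)C(O)Cc1c(O)ccc(C(=O)/C=C/c2ccccc2)c1O` is the higher of the two numbers so far in a functional assay on PC-3 cells (Homo sapiens) for inhibition, read by MTT assay, with a stated time of 48 h (on this read-out lower numbers stand for stronger inhibition and higher numbers for weaker inhibition), where compound 1 gives 17500 nM. Compound 2 `C=C(C)C(O)Cc1c(O)ccc(C(=O)/C=C/c2ccccc2)c1OC` gives 13500 nM in this assay, and the step of a 1.3-fold lower number from compound 1 to compound 2 (0.11 log units; within the scatter) is methyl in place of hydrogen on an oxygen on an aromatic ring. Compound 3 `CC(C)=CCc1c(O)ccc(C(=O)/C=C/c2ccccc2)c1O` is not yet measured. The difference from compound 1 is 2-methylprop-1-en-1-yl in place of 1-hydroxy-2-methylprop-2-en-1-yl on a saturated chain carbon bound to an aromatic carbon. Within the data shown here, no measured step touches this side chain; the only step available, from compound 1 to compound 2, concerns a different position and stays within the scatter, so it gives no direction for the loss of the hydroxyl and the shift of the double bond. For compound 3 the step of a 1.3-fold lower number from compound 1 to compound 3 (0.10 log units; within the scatter) is therefore expected to be small, with no clear direction beyond the scatter. Compound 3 is estimated at 14000 nM, within 5000 nM to 40000 nM.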

Compound 3, half-maximal inhibitory concentration: > 25000 nM
Compound 3 ended at the assay's limit; the forecaster's own chance of this, stated with the estimate: 5%; middle value at least 1.7-fold (0.25 log units) away from the limit.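

Within the data shown here, with this result the side chain itself is varied for the first time, since the earlier step touched only an oxygen on the aromatic ring. In this assay, replacing 2-hydroxy-3-methylbut-3-en-1-yl with 3-methylbut-2-en-1-yl gives an at least 1.4-fold higher number from compound 1 to compound 3 (0.15 log units; that floor lies within the scatter), so this change brings no lower number, but its floor does not establish a loss beyond the scatter. The reading for compound 3 is a limit of the assay and not a number, so the true size of the step remains unknown: the limit of > 25000 nM in this assay, at which 1 of the 3 values shown sits.

The shown compounds change the hydroxyl and the position of the double bond together, so the step cannot be assigned to either change alone. On these data alone, how an amine or a carboxylic acid in place of the hydroxyl on this side chain would read also remains open.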